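Clearance expected to hold after swapping dimethylcarbamoyl for pyrazin-2-yl

The source may hold more compounds than are shown below. What is called first, only, known or untested is meant among the compounds shown, and "the series" means these compounds.

Measured in an in vivo ADME assay on the whole organism (strain 129/SvEvBrd x C57BL/6) for pharmacokinetics, with Mus musculus as the target, at a dose of 1 mg/kg by the intravenous route; a higher number here means faster removal of the compound, a lower number slower removal:
- Compound 1 `CC(=O)c1nc([C@@H](O)[C@H](O)[C@H](O)CO)c(C)[nH]1` gives 7 mL/min/kg
- Compound 2 `CN(C)C(=O)c1nc([C@@H](O)[C@H](O)[C@H](O)CO)c[nH]1` gives 11.3 mL/min/kg
- Compound 3 `OC[C@@H](O)[C@@H](O)[C@H](O)c1c[nH]c(-c2ncn(Cc3ccccc3)n2)n1` gives 16.4 mL/min/kg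

Compound 2 lies within the usual scatter of both compound 1 and compound 3. Compound 4 `OC[C@@H](O)[C@@H](O)[C@H](O)c1c[nH]c(-c2cnccn2)n1` has pyrazin-2-yl in place of dimethylcarbamoyl on an aromatic carbon. Among the compounds with values here, no measured pair here differs in one place only, so this expectation has little to rest on. Compound 3 also carries a ring-bearing group at that place, and at 16.4 mL/min/kg it stays within the scatter of compound 2. The expected step of a 1.1-fold higher number from compound 2 to compound 4 (0.03 log units; within the scatter) in this assay is therefore none beyond the scatter. Compound 4 is estimated at 12 mL/min/kg (expected range 5 mL/min/kg to 28 mL/min/kg).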

Compound 4, clearance: 13.4 mL/min/kg
Beside the measured number, compound 4's estimate is 1.1-fold (0.05 log units) below it, within the range that was stated.
By their numbers in this assay, from the lowest: compounds 1, 2, 4 and 3 (each within the scatter of the next, the first and the last beyond it).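

In this assay, replacing dimethylcarbamoyl with pyrazin-2-yl gives a 1.2-fold higher number from compound 2 to compound 4 (0.07 log units; within the scatter) in the only pair shown that differs in one place. At this aromatic carbon between two ring nitrogen atoms, then, a group with no ring and a six-membered aromatic ring with 2 hetero atoms give clearances within the scatter of each other. Nothing measured here explains this result.

One pair cannot show how far this tolerance extends. An amine, a carboxylic acid or a longer chain at this place could still behave differently.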